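Thiophen-2-yl in place of furan-2-yl

This account rests on a few compounds, and the source may have more. Where it says the series, first, only, none or still open, it means among the compounds named here.

In a functional assay on CCRF-CEM cells (Homo sapiens), read by MTT assay, with a stated time of 72 h (on this read-out higher numbers stand for weaker inhibition and lower numbers for stronger inhibition), compound 1 (`COc1ncnc2c1c(-c1ccccc1)cn2[C@@H]1O[C@H](CO)[C@@H](O)[C@H]1O`) reads > 20000 nM and this is a limit of the assay, not a number. Compound 2 (`CNc1ncnc2c1c(-c1ccco1)cn2[C@@H]1O[C@H](CO)[C@@H](O)[C@H]1O`) gives 180 nM in the same test. Among the compounds with values here, that is the only true number available, so compound 2 can be set only against the limit of compound 1, on the side of stronger inhibition. Compound 3 (`CNc1ncnc2c1c(-c1cccs1)cn2[C@@H]1O[C@H](CO)[C@@H](O)[C@H]1O`) has not yet been measured. It differs from compound 2 in one place, with thiophen-2-yl in place of furan-2-yl on an aromatic carbon of the five-membered aromatic ring with 1 nitrogen (thiophen-2-yl in place of furan-2-yl on an aromatic carbon). Within the data shown here, no measured pair shows what this exchange does in this assay so the expectation rests on the close match between the two groups. Starting from compound 2 at 180 nM no change beyond the usual scatter is expected. The estimated change is small (a 1.2-fold lower number from compound 2 to compound 3 (0.08 log units; within the scatter)) and carries no firm direction. Compound 3 is estimated at 150 nM (expected range 40 nM to 600 nM).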

Compound 3, half-maximal inhibitory concentration: > 20000 nM
Compound 3: only a limit was reported (the forecaster's own chance of this, stated with the estimate: 5%); middle value at least 130-fold (2.12 log units) away from the limit.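

In this assay, the exchange of furan-2-yl for thiophen-2-yl on an aromatic carbon of the five-membered aromatic ring with 1 nitrogen gives an at least 110-fold higher number from compound 2 to compound 3 (2.04 log units; beyond the scatter). The two groups have the same count of heavy atoms, donors and acceptors, carry no net charge and differ only in having oxygen or sulfur in the ring, so this position responds sharply to a change that leaves all of those counts untouched. The reading of compound 3 is a limit of the assay and not a number, which means the step fixes only a minimum for the loss and not its true size: the limit of > 20000 nM in this assay, at which 2 of the 3 values shown sit.

The compounds shown leave open whether the sulfur atom itself matters or whether furan-2-yl is a special case, and how a thiophen-3-yl, furan-3-yl or pyrrol-2-yl group would read at this position. Compound 1 differs from compound 2 and compound 3 in more than one place, so it cannot settle how a phenyl group compares with either ring on the same core.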